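This account rests on a few compounds, and the source may have more. Where it says the series, first, only, none or still open, it means among the compounds named here.

Among the compounds with values here, in a functional assay on MGC-803 cells (Homo sapiens) for antiproliferative activity, read by CellTiter-Glo, with a stated time of 72 h (on this read-out higher numbers stand for weaker inhibition and lower numbers for stronger inhibition), compound 1 `O=C(NO)c1ccc(/C=C/c2ccnc(-c3ccccc3O)c2)cc1` gives 1420 nM, the lower of the two numbers measured so far. Compound 2 `COc1ccc(-c2cc(/C=C/c3ccc(C(=O)NO)cc3)ccn2)cc1` gives 3510 nM. Compound 3 `O=C(/C=C/c1ccc(/C=C/c2ccnc(-c3ccccc3O)c2)cc1)NO` has not yet been measured. It differs from compound 1 at one place: 2-(hydroxycarbamoyl)ethenyl in place of hydroxycarbamoyl on an aromatic carbon. In words, 2-(hydroxycarbamoyl)ethenyl stands in place of hydroxycarbamoyl on an aromatic carbon, para to a large group. Within the data shown here, the only measured step, a 2.5-fold higher number from compound 1 to compound 2 (0.39 log units; beyond the scatter), puts 4-methoxyphenyl in place of 2-hydroxyphenyl at a different place, so it does not test this change and serves only as a guide to size. The data give no direction, so a modest move toward stronger inhibition, similar in size to that step, is a tentative expectation. The expected change is a 2.4-fold lower number from compound 1 to compound 3 (0.37 log units; beyond the scatter). In this assay, the estimate for compound 3 is 600 nM, with an expected range from 120 nM to 2500 nM.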

Compound 3, half-maximal inhibitory concentration: > 10000 nM
Compound 3: a limit, no number; the forecaster's own chance of this, stated with the estimate: 3%; middle value at least 16-fold (1.22 log units) from the limit.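

In this assay, within the data shown here, this is the first change at the hydroxycarbamoyl end of the molecule, on the aromatic carbon para to a large group, and it has a clear effect. Putting 2-(hydroxycarbamoyl)ethenyl in place of hydroxycarbamoyl gives an at least 7.0-fold higher number from compound 1 to compound 3 (0.84 log units; beyond the scatter), so activity at this place depends strongly on the group attached, whereas the earlier step, a 2.5-fold higher number from compound 1 to compound 2 (0.39 log units; beyond the scatter), concerned only a different place. The value of compound 3 is a limit of the assay and not a number, so the full size of this step stays unknown: the limit of > 10000 nM in this assay, at which 1 of the 3 values shown sits.

The compounds shown cannot tell whether the loss comes from the added length or from the added double bond, since the two arrive together. A saturated chain carrying the hydroxycarbamoyl, or a carboxylic acid in its place, lies outside the compounds shown, so how either would behave at this position remains open.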